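The compounds below may be only part of what the source reports. "The series", "measured", "known", "first", "only" and "open" are said of these compounds alone.

Compound 1, `CCCCCC(=O)Nc1ccc(S(=O)(=O)Oc2ccccc2C(C)C)cc1`: 6700 nM
Compound 2, `CCCCCC(=O)Nc1ccc(S(=O)(=O)Oc2ccccc2I)cc1`: 11000 nM
Compound 3, `CC(C)c1ccccc1OS(=O)(=O)c1ccc(NC(=O)CCCCl)cc1`: 5100 nM

All three were tested in a functional assay on M21 cells (Homo sapiens) for antiproliferative activity, read by sulforhodamine B assay, with a stated time of 48 h; on this read-out lower numbers stand for stronger inhibition and higher numbers for weaker inhibition. Compound 1 and compound 2 differ in one place, (iodo in place of isopropyl on an aromatic carbon), which gave a 1.6-fold higher number from compound 1 to compound 2 (0.22 log units; within the scatter). Compound 3 has a different core from compound 1, (chloro in place of ethyl on a saturated chain carbon, three bonds along the chain from a carbonyl carbon), and this gave a 1.3-fold lower number from compound 1 to compound 3 (0.12 log units; within the scatter). Compound 4, `O=C(CCCCl)Nc1ccc(S(=O)(=O)Oc2ccccc2I)cc1`, has not yet been measured; it differs from compound 3 by iodo in place of isopropyl on an aromatic carbon, the same change that turns compound 1 into compound 2, at the same place. A similar, small step is expected from compound 3 to compound 4, because the earlier step was a 1.6-fold higher number from compound 1 to compound 2 (0.22 log units; within the scatter). The estimated step is a 1.6-fold higher number from compound 3 to compound 4 (0.21 log units; within the scatter). Compound 4 is therefore expected to give about 8200 nM in this assay, with a likely range from 4000 nM to 17000 nM.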

Compound 4, half-maximal inhibitory concentration: 7200 nM
Compound 4: the middle estimate sits 1.1-fold (0.06 log units) above what was measured, within the range that was stated.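

Replacing isopropyl with iodo gave a 1.4-fold higher number from compound 3 to compound 4 (0.15 log units; within the scatter), and this step matches the one seen earlier on the other core: the same change on two cores in this assay, a 1.6-fold higher number (0.22 log units; within the scatter) from compound 1 to compound 2 and a 1.4-fold higher number (0.15 log units; within the scatter) from compound 3 to compound 4, 1.2-fold (0.07 log units) apart, within the scatter of two such steps
Replacing ethyl with chloro gave a 1.5-fold lower number from compound 2 to compound 4 (0.18 log units; within the scatter), and this step also matches its earlier counterpart: the same change on two cores in this assay, a 1.3-fold lower number (0.12 log units; within the scatter) from compound 1 to compound 3 and a 1.5-fold lower number (0.18 log units; within the scatter) from compound 2 to compound 4, 1.2-fold (0.07 log units) apart, within the scatter of two such steps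
In this assay, among the compounds shown here, each change therefore has a similar size on both cores, but every step lies within the scatter, so this shows only that neither change made a large difference here, not that either one truly shifts activity.

The compounds shown leave open what a methoxy group in place of the iodo, or an amine or a carboxylic acid in place of the chloro, would do to these numbers. They also leave open whether these small steps would hold in other cell types.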